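The source may report more compounds than this note shows. Statements on the series, on what has been measured and on what is new or still open speak of the compounds shown alone.

Measured in a functional assay on HCT-116 cells (Homo sapiens) for antiproliferative activity, read by MTT assay, with a stated time of 48 h; a lower number here means a stronger inhibitor, a higher number a weaker inhibitor:
- Compound 1 `COc1ccc(N(C)c2ccnc(Cl)n2)cc1OCCBr`: 5670 nM
- Compound 2 `COc1ccc(N(C)c2ccnc(Cl)n2)cc1OCCCCCBr`: > 10000 nM (a limit, not a number)

Compound 2 has no exact value and stands at the limit of > 10000 nM in this assay, at which 1 of the 2 values shown sits.

The next structure is compound 3 `COc1ccc(N(C)c2ccnc(Cl)n2)cc1OCCCCC[Se]C#N`. It keeps the chain of compound 2 and differs at its end: a group of 3 heavy atoms (1 carbon, 1 nitrogen, 1 selenium; no ring) in place of one bromine atom, on a saturated chain carbon, five bonds along the chain from an oxygen on an aromatic ring.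

For the measured compounds named here, only one measured step is available, an at least 1.7-fold higher number from compound 1 to compound 2 (0.24 log units; that floor lies within the scatter). That step changes the chain and keeps the bromine, so it bears on this swap only indirectly. Going by the values given here, no measured pair replaces the bromine, which leaves the size of the new step uncertain.

Compound 1, at 5670 nM, shows that a compound with this core can give a real number in this assay. A moderate move to a lower number is therefore expected, though compound 3 could also stay at the limit.

The expected change is an at least 3.3-fold lower number from compound 2 to compound 3 (0.52 log units; beyond the scatter).

For compound 3, the estimated value is 3000 nM, with an expected range from 600 nM to 10000 nM.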

Compound 3, half-maximal inhibitory concentration: > 10000 nM
Compound 3 gave a limit, no number; the forecaster's own chance of this, stated with the estimate: 25%; at least 3.3-fold (0.52 log units) between middle value and limit.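

Compound 3 also ends in a limit, so putting the group of carbon, nitrogen and selenium in place of the bromine, five bonds along the chain from an oxygen on an aromatic ring, does not bring a real number into reach in this assay, and the two limits leave the step between compound 2 and compound 3 unreadable. For the compounds shown here, the one step that can be read is an at least 1.7-fold higher number from compound 1 to compound 3 (0.24 log units; that floor lies within the scatter); it is only a floor, and it changes the chain and its end together, so it cannot be assigned to either change. The two compounds with the longer chain now share one limit: the limit of > 10000 nM in this assay, at which 2 of the 3 values shown sit.

From the compounds shown here alone, it remains open whether the selenium-bearing end would give a real number on the shorter chain of compound 1, where the bromine version does give one. Going by these compounds, it also remains open whether a different end on the longer chain, such as an amine or a carboxylic acid, would give a real number in this assay.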